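The source may hold more compounds than are shown below. What is called first, only, known or untested is meant among the compounds shown, and "the series" means these compounds.

Compound 2, `N#CC1=C(N)Oc2cc3oc(-c4ccccc4)cc(=O)c3c(O)c2C12C(=O)N(c1ccccc1)c1ccccc12`, has been tested in a functional assay on A549 cells (Homo sapiens) for antiproliferative activity, read by MTT assay, with a stated time of 48 h; a lower number here means a stronger inhibitor, a higher number a weaker inhibitor. In this assay compound 2 gives > 50000 nM, which is a limit of the assay and not a number. Compound 1, `CN1C(=O)C2(C(C#N)=C(N)Oc3cc4oc(-c5ccccc5)cc(=O)c4c(O)c32)c2cccc(Cl)c21`, gives > 50000 nM in this assay, again only a limit. Compound 3, `CCN1C(=O)C2(C(C#N)=C(N)Oc3cc4oc(-c5ccccc5)cc(=O)c4c(O)c32)c2cccc(C)c21`, gives > 50000 nM, also a limit. So far every result is summarised by the limit of > 50000 nM in this assay, at which 3 of the 3 values shown sit, and no step between measured compounds can be stated. Compound 4, `N#CC1=C(N)Oc2cc3oc(-c4ccccc4)cc(=O)c3c(O)c2C12C(=O)Nc1ccccc12`, differs from compound 2 by hydrogen in place of phenyl on an amide-type nitrogen in a ring. Since nothing has been resolved beyond the limit, the expected step that the limit leaves unreadable from compound 2 to compound 4 is none beyond the usual scatter, most likely another limit. Compound 4 is therefore estimated at 80000 nM, expected to lie between 20000 nM and 300000 nM.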

Compound 4, half-maximal inhibitory concentration: 37600 nM
Estimate against measurement, compound 4: 2.1-fold (0.33 log units) above; measured number inside the range.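

In this assay, replacing phenyl with hydrogen on the amide-type nitrogen in a ring gives an at least 1.3-fold lower number from compound 2 to compound 4 (0.12 log units; that floor lies within the scatter). Compound 4 thus gives the first reading at this position that is a number and not a limit, although the size of the step remains unresolved: the limit of > 50000 nM in this assay, at which 3 of the 4 values shown sit.

The compounds shown leave open how a benzyl or an acetyl group on this nitrogen would read. Compound 1 and compound 3 also differ from compound 4 elsewhere, so they do not isolate the effect of a group at this position.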